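A few compounds are considered here, and "the series" means these few. Any claim that something is new, unique, unknown or untested is made for them only; others in the source may bear on it.

Measured so far in a functional assay on A549 cells (Homo sapiens) for cytotoxicity, read by MTT assay, with a stated time of 24 h; a higher number here means a weaker inhibitor, a lower number a stronger inhibitor:

Compound 1 `Cc1ccc2oc(-c3ccc(NC(=O)CN4CCN(CCN(C)C)CC4)cc3)nc2c1`: in this assay compound 1 gives 3660 nM.
Compound 2 `Cc1ccc2oc(-c3ccc(NC(=O)CN4CCN(CCN(C)C)CC4)c(C)c3)nc2c1`: in this assay compound 2 gives 11000 nM.
Compound 3 `Cc1cc(-c2nc3ccccc3o2)ccc1NC(=O)CN1CCN(CCCN(C)C)CC1`: in this assay compound 3 gives 22100 nM.

Compound 4 `CN(C)CCCN1CCN(CC(=O)Nc2ccc(-c3nc4ccccc4o3)cc2)CC1` has not yet been measured. It differs from compound 3 in one place: hydrogen in place of methyl on an aromatic carbon. The same change has already been measured once, from compound 2 to compound 1: hydrogen in place of methyl on an aromatic carbon, and there it gave a 3.0-fold lower number from compound 2 to compound 1 (0.48 log units; beyond the scatter). The two places are not identical word for word: in compound 2 the methyl sits meta to a 5-methyl-1,3-benzoxazol-2-yl group, in compound 3 meta to a 1,3-benzoxazol-2-yl group, so the change is of the same kind rather than the same. How the cores of compound 2 and compound 3 differ is not broken down here; their values lie within the usual scatter of each other. Compound 3 gives the highest number of the three, and its gap to compound 1 lies beyond the scatter.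

Carrying the measured step of a 3.0-fold lower number from compound 2 to compound 1 (0.48 log units; beyond the scatter) onto compound 3, the expected step is a 2.9-fold lower number from compound 3 to compound 4 (0.47 log units; beyond the scatter). The expectation rests on a single measured instance, so the range is kept wide. For compound 4 the estimate in this assay is 7500 nM, between 3000 nM and 18000 nM.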

Compound 4, half-maximal inhibitory concentration: 18300 nM
Compound 4: the middle estimate sits 2.4-fold (0.39 log units) below what was measured, outside the stated range (above it).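

In this assay, hydrogen in place of methyl on an aromatic carbon gives a 1.2-fold lower number from compound 3 to compound 4 (0.08 log units; within the scatter), so on this core the change gives a step that cannot be told apart from repeat-measurement noise. Set beside the earlier instance, the two steps do not separate: the same change on two cores in this assay, a 3.0-fold lower number (0.48 log units; beyond the scatter) from compound 2 to compound 1 and a 1.2-fold lower number (0.08 log units; within the scatter) from compound 3 to compound 4, 2.5-fold (0.40 log units) apart, within the scatter of two such steps. With only two instances, this shows neither that the step carries over at a fixed size nor that its size depends on the core, and the cores of the two pairs differ in more than one place, so no single structural difference can be tied to the two sizes.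

Still open, as far as these compounds go, is how this assay responds at this same aromatic carbon to a group other than methyl, such as chlorine, fluorine or methoxy, and whether such a group behaves alike on both cores. Also open, from the compounds shown here alone, is whether a third matched pair, for instance one carrying a longer chain to the terminal amine or a cyclic amine such as morpholine in place of the dimethylamino end, would bring the size of this step any closer to being settled.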